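The source may hold more compounds than are shown below. What is called first, only, known or untested is meant among the compounds shown, and "the series" means these compounds.

In a functional assay on M21 cells (Homo sapiens) for antiproliferative activity, with a stated time of 48 h (on this read-out higher numbers stand for weaker inhibition and lower numbers for stronger inhibition), compound 1 `CC(C)(C)c1ccc(CNC(=O)NCCCCl)cc1` gives 11000 nM. Compound 2 `CCNC(=O)NCc1ccc(C(C)(C)C)cc1` returns only a limit in this assay, > 100000 nM. This puts compound 2 at the limit of > 100000 nM in this assay, at which 1 of the 2 values shown sits. Among the measured compounds shown here, the one measured step is an at least 9.0-fold higher number from compound 1 to compound 2 (0.95 log units; beyond the scatter), the loss of the chlorine-bearing chain. Compound 3 `CC(C)(C)c1ccc(CNC(=O)CCCl)cc1` differs from compound 2 by 2-chloroethyl in place of ethylamino on a carbonyl carbon, so a chlorine on a short chain comes back, though the urea becomes an amide. For the measured compounds named here, no measured step covers that second part. Compound 3 is therefore expected to gain about an at least 6.6-fold lower number from compound 2 to compound 3 (0.82 log units; beyond the scatter) in this assay. Compound 3 is estimated at 15000 nM, between 3000 nM and 100000 nM.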

Compound 3, half-maximal inhibitory concentration: > 100000 nM
Compound 3: no number, only a limit; the forecaster's own chance of this, stated with the estimate: 25%; at least 6.6-fold (0.82 log units) between middle value and limit.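

Compound 3 gives > 100000 nM in this assay, which is a limit and not a number, so the step from compound 2 cannot be read. A chlorine on a short chain is thus not enough on its own: 2-chloroethyl in place of (3-chloropropyl)amino on a carbonyl carbon gives an at least 9.0-fold higher number from compound 1 to compound 3 (0.95 log units; beyond the scatter). Compound 3 joins compound 2 at the ceiling of the assay: the limit of > 100000 nM in this assay, at which 2 of the 3 values shown sit.

Compound 3 differs from compound 1 in both the amino nitrogen and the chain, and the compounds shown do not separate the two. Going by these compounds, a 3-chloropropyl group on the carbonyl carbon or an unchlorinated propylamino group remains open.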